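Swapping Cyano for Methoxy on a Dibromo Core

The source may hold more compounds than are shown below. What is called first, only, known or untested is meant among the compounds shown, and "the series" means these compounds.

Compound 1, `O=C1CC(c2ccc(Br)cc2)Nc2c(Br)cc(Br)cc21`, in this test: > 100000 nM.
Compound 2, `O=C1CC(c2ccc([N+](=O)[O-])cc2)Nc2c(Br)cc(Br)cc21`, in this test: > 100000 nM.
Compound 3, `N#Cc1ccc(C2CC(=O)c3cc(Br)cc(Br)c3N2)cc1`, in this test: > 100000 nM.

All three of these values come from a functional assay on MCF7 cells (Homo sapiens) for cytotoxicity, read by sulforhodamine B assay, with a stated time of 48 h; on this read-out lower numbers stand for higher toxicity in this test and higher numbers for lower toxicity in this test. Each of them is a limit of the assay rather than a number, as summed up by the limit of > 100000 nM in this assay, at which 3 of the 3 values shown sit. Where nitro replaces bromo on an aromatic carbon, the result is a step that the two limits leave unreadable from compound 1 to compound 2. The same holds for a step that the two limits leave unreadable from compound 1 to compound 3, where cyano replaces bromo, and for a step that the two limits leave unreadable from compound 2 to compound 3, where cyano replaces nitro. Compound 3 therefore stands only at a limit, alongside two other limits, and no ordering among the three can be read.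

Compound 4, `COc1ccc(C2CC(=O)c3cc(Br)cc(Br)c3N2)cc1`, differs from compound 3 in one place: methoxy in place of cyano on an aromatic carbon. Among the compounds with values here, none of the measured steps can be read in size, so they give no basis for expecting a step in this assay in either direction. The step from compound 3 to compound 4 is therefore expected to be a step that the limit leaves unreadable from compound 3 to compound 4. Compound 4 is expected to give about 150000 nM in this assay, within a range of 40000 nM to 600000 nM, most likely reported again as a limit.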

Compound 4, concentration lethal to 50% of the cells: > 100000 nM
Compound 4: no number, only a limit (the forecaster's own chance of this, stated with the estimate: 85%); the middle value does not contradict the limit.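

Compound 4 also gives only a limit, so none of its steps from compound 1, compound 2 or compound 3 can be read, and no order among the four appears: the limit of > 100000 nM in this assay, at which 4 of the 4 values shown sit. The compounds shown leave open whether bromo, nitro, cyano and methoxy differ at all in this assay, and whether any group on the shared core would give a readable value.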